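Swapping Both Ring Stereocentres on a Cyclopropyl Amide

The compounds below may be only part of what the source reports. "The series", "measured", "known", "first", "only" and "open" are said of these compounds alone.

Measured so far in an assay on SH-EP1 cells for displacement of a labelled ligand from Neuronal acetylcholine receptor; alpha4/beta2 (Homo sapiens), read by scintillation counting; a lower number here means a stronger inhibitor, a higher number a weaker inhibitor:
- compound 1, `CCCC(=O)N1CC2CC(C1)N2`, gives 14 nM
- compound 2, `CC(C)C(=O)N1CC2CC(C1)N2`, gives 130 nM
- compound 3, `C[C@@H]1C[C@@H]1C(=O)N1CC2CC(C1)N2`, gives 22 nM

All three share the same bicyclic amine core and differ only in the group attached to the carbonyl carbon. Compound 3 stands second of the three numbers: its nearest neighbour is compound 1, with a 1.6-fold higher number from compound 1 to compound 3 (0.20 log units; within the scatter), a gap that sits inside the usual scatter, while its furthest is compound 2, with a 5.9-fold lower number from compound 2 to compound 3 (0.77 log units; beyond the scatter). Among the compounds with values here, the one clearly separated step among the measured compounds is a 9.3-fold higher number from compound 1 to compound 2 (0.97 log units; beyond the scatter).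

Compound 4, `C[C@H]1C[C@H]1C(=O)N1CC2CC(C1)N2`, is the mirror-image partner of compound 3: the two compounds have the same atoms and bonds; at least one stereo element is drawn with a configuration in one of them and without one in the other: 2 of 4 stereo elements differ; a stereocentre at a saturated ring carbon is drawn R in compound 3 and S in compound 4; a stereocentre at a saturated ring carbon is drawn S in compound 3 and R in compound 4. Within the data shown here, no measured step changes a stereocentre, so none of the three bears directly on this move; the steps so far only show that the carbonyl substituent matters, and that the cyclopropyl of compound 3 lands close to compound 1. Mirror images can differ widely or not at all, and nothing here tells which. The expectation for compound 4 in this assay is therefore a number close to that of compound 3, with a range wide enough to admit a real loss, expressed as a 1.8-fold higher number from compound 3 to compound 4 (0.26 log units; within the scatter). Compound 4 is estimated at 40 nM, between 10 nM and 200 nM.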

Compound 4, inhibition constant: 7 nM
The estimate for compound 4 lay 5.7-fold (0.76 log units) above the measured number; measured number outside the range, below it.
By their numbers in this assay, from the lowest: compounds 4, 1 and 3 (each within the scatter of the next, the first and the last beyond it); then compound 2.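

In this assay, within the data shown here, the arrangement of the two ring stereocentres in the 2-methylcyclopropyl group makes a real difference: inverting both gives a 3.1-fold lower number from compound 3 to compound 4 (0.50 log units; beyond the scatter), so this position tells apart two compounds with the same atoms and bonds, something no earlier step could show. Against isopropyl, the better of the two forms goes further, with a 19-fold lower number from compound 2 to compound 4 (1.27 log units; beyond the scatter), while a 2.0-fold lower number from compound 1 to compound 4 (0.30 log units; within the scatter) shows that even this form does not separate from the propyl chain, so the ring gives a clear edge over the branched group only. The size of the stereo step carries one caution, since the two drawings may not define every centre in the same way: the fact that one of compounds 3 and 4 is drawn with a defined configuration and the other without, at the place where they differ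

Still open, going by these compounds, is whether the methyl group is needed for the stereocentres to matter, which a plain cyclopropyl or a 2-ethylcyclopropyl group could test. It is also unknown whether a longer chain such as butyl would match the propyl chain or fall away towards isopropyl.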